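A Phenyl Group Enters the Core of Compound 2

This account rests on a few compounds, and the source may have more. Where it says the series, first, only, none or still open, it means among the compounds named here.

In a functional assay on HeLa cells (Homo sapiens) for antiproliferative activity, read by sulforhodamine B assay (on this read-out lower numbers stand for stronger inhibition of growth and higher numbers for weaker inhibition of growth), compound 1, `c1ccc(COC[C@H]2OCC[C@@H](OCc3ccccc3)[C@@H]2OCc2ccccc2)cc1`, gives 33300 nM. Compound 2, `O[C@H]1CO[C@H](COCc2ccccc2)[C@@H](OCc2ccccc2)[C@@H]1OCc1ccccc1`, reaches only the assay limit, > 50000 nM. Compound 3, `O[C@@H]1[C@@H](OCc2ccccc2)[C@H](OCc2ccccc2)[C@@H](COCc2ccccc2)O[C@@H]1CC1CCCCC1`, likewise reaches only the assay limit, > 50000 nM.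

Compound 2 thus stands at the limit, and the same holds for compound 3, as the limit of > 50000 nM in this assay, at which 2 of the 3 values shown sit, records. The step from compound 1 is an at least 1.5-fold higher number from compound 1 to compound 2 (0.17 log units; that floor lies within the scatter), and the step onward to compound 3 is a step that the two limits leave unreadable from compound 2 to compound 3. Compound 4, `O[C@@H]1[C@@H](OCc2ccccc2)[C@H](OCc2ccccc2)[C@@H](COCc2ccccc2)O[C@H]1c1ccccc1`, carries the change (phenyl in place of hydrogen on a saturated ring carbon). For the measured compounds named here, the only step at that same ring carbon, to compound 3, ended at the limit, so the estimated step is a step that the limit leaves unreadable from compound 2 to compound 4, with no change beyond the scatter expected. Compound 4 is therefore expected to give 60000 nM, within 25000 nM to 150000 nM.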

Compound 4, concentration for 50% growth inhibition: > 50000 nM
Compound 4: no number, only a limit; the forecaster's own chance of this, stated with the estimate: 70%; the middle value lies beyond the limit too.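

No step from compound 2 to compound 4 can be read, since both stand at a limit and give no number: the limit of > 50000 nM in this assay, at which 3 of the 4 values shown sit.

The compounds shown leave open whether phenyl in place of hydrogen changes growth inhibition at all, and how compound 2, compound 3 and compound 4 rank.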